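Cytotoxicity notes: dithiolane-triazole coumarin series, step to compound 4

The compounds below may be only part of what the source reports. "The series", "measured", "known", "first", "only" and "open" are said of these compounds alone.

Measured so far:
compound 1 `O=C(CCCCC1CCSS1)NCc1cn(CCCOc2ccc3ccc(=O)oc3c2)nn1` — 40%
compound 2 `Cc1cc(=O)oc2cc(OCCCn3cc(CNC(=O)CCCCC4CCSS4)nn3)ccc12` — 69.4%
compound 3 `CC(=O)c1cc2ccc(OCCCn3cc(CNC(=O)CCCCC4CCSS4)nn3)cc2oc1=O` — 38%

The read-out throughout is a functional assay on PC-12 cells (Rattus norvegicus) for cytotoxicity, read by MTT assay, with stated times of 3 h and 2 h, tested at 10 uM; a lower number here means a weaker effect, a higher number a stronger effect of the compound at the concentration tested. Compound 3 gives the smallest number of the three, 38%, but its gap to compound 1 is within the scatter, so the two cannot be ordered; only compound 2 stands apart, a number 29.4 percentage points higher from compound 1 to compound 2 (beyond the scatter).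

The next compound is compound 4 `CCOC(=O)c1cc2ccc(OCCCn3cc(CNC(=O)CCCCC4CCSS4)nn3)cc2oc1=O`. Against compound 3 the change is ethoxy in place of methyl on a carbonyl carbon.

Two measured steps exist. The step of a number 29.4 percentage points higher from compound 1 to compound 2 (beyond the scatter) concerns a methyl on an aromatic carbon and does not touch the carbonyl in question. The step of a number 2 percentage points lower from compound 1 to compound 3 (within the scatter) installs the acetyl itself, and that installation moved nothing beyond the scatter. Among the measured compounds shown here, no measured step swaps one substituent for another on this carbonyl carbon, so the ethoxy-for-methyl exchange has no direct precedent. Given that the acetyl-bearing compound 3 sits within the scatter of the unsubstituted compound 1, a further change at that same carbonyl is expected to give a step of a number 2 percentage points higher from compound 3 to compound 4 (within the scatter) in this assay, that is, none beyond the scatter. Compound 4 is therefore estimated at 40%, with a range of 26% to 58%.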

Compound 4, a percentage reported as activity, at one concentration (the size of the read-out at that concentration, not a potency): 36.1%
Compound 4: middle estimate off by 3.9 percentage points, on the high side; the range from low to high includes it.
By their numbers in this assay, from the lowest: compounds 4, 3 and 1 (each within the scatter of the next); then compound 2.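

In this assay, among the compounds shown here, ethoxy in place of methyl on the carbonyl carbon gives a number 1.9 percentage points lower from compound 3 to compound 4 (within the scatter), which is the first measured exchange of one substituent for another at this carbonyl and shows that going from acetyl to ethoxycarbonyl leaves the read-out within the scatter. Ethoxycarbonyl in place of hydrogen on the aromatic carbon gives a number 3.9 percentage points lower from compound 1 to compound 4 (within the scatter), so compound 3 and compound 4 now both stand within the scatter of compound 1, while the methyl change remains the only listed step beyond it, with a number 29.4 percentage points higher from compound 1 to compound 2 (beyond the scatter) as its size. No measurement accompanying these compounds bears on the reason for this result.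

The compounds shown leave open whether the same flat read-out would hold for a carboxylic acid or a primary amide on this carbonyl carbon, or for a longer chain such as butoxy in place of ethoxy. Also open, on these data alone, is whether the methyl change that raised the number in compound 2 would have the same size on a core that also carries acetyl or ethoxycarbonyl.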